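The source may report more compounds than this note shows. Statements on the series, on what has been measured and on what is new or still open speak of the compounds shown alone.

Measured compounds:
- compound 1, `COc1ccc(OCCCCOc2ccc(C(=O)CC(C)(C)C)c(O)c2C)cc1C(=O)O`: 490 nM
- compound 2, `Cc1c(O[C@@H](C)COc2ccc(F)c(C(=O)O)c2)ccc(C(=O)CC(C)(C)C)c1O`: 1120 nM
- compound 3, `COc1cc(C(=O)O)ccc1OC[C@H](C)COc1ccc(C(=O)CC(C)(C)C)c(O)c1C`: 512 nM

The three compounds were measured in an assay for positive allosteric modulation of metabotropic glutamate receptor 3 (Rattus norvegicus); a lower number here means that less compound is needed, a higher number that more compound is needed for the effect. All three share a core carrying a carboxy group on an aromatic ring. In this assay compound 3 gives 512 nM, which is the second highest of the three numbers. Its number and that of compound 1 lie within the usual scatter of each other, so no order between them can be read. Compound 2, with 1120 nM, gives a higher number than compound 3, and that gap lies beyond the scatter.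

Compound 4, `COc1ccccc1OC[C@H](C)COc1ccc(C(=O)CC(C)(C)C)c(O)c1C`, has not yet been measured. It differs from compound 3 in one place: hydrogen in place of carboxy on an aromatic carbon. For the measured compounds named here, no pair of measured compounds shows the effect of this change, since every measured compound keeps the carboxy group, so there is no step to lean on. My expectation for this assay is a step of a 3.1-fold higher number from compound 3 to compound 4 (0.49 log units; beyond the scatter), a higher number for compound 4, because compound 3 gives 512 nM while carrying the carboxy group that every measured compound holds and removing a group shared by all of them more often costs than gains. For compound 4 the estimate is 1600 nM, with a range from 500 nM to 6000 nM.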

Compound 4, half-maximal effective concentration: "not active" (no number reported)
No number was reported for compound 4, and the estimate cannot be compared.
By their numbers in this assay, from the lowest: compounds 1 and 3 (each within the scatter of the next); then compound 2.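

For the compounds shown here, compound 4 is reported as "not active" in (this assay) with no number, so no step from compound 3 to compound 4 can be read. Nothing measured here offers an explanation for this result. The compounds shown leave open how large the effect of replacing carboxy with hydrogen is when expressed as a number.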